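This account rests on a few compounds, and the source may have more. Where it says the series, first, only, none or still open, it means among the compounds named here.

Measured compounds:
compound 1 `CCCCc1ccc2[nH]c(-c3ccc(OC)cc3)c(C=O)c2c1`: 22 nM
compound 2 `CCCCc1ccc2[nH]c(-c3ccc(C(F)(F)F)cc3)c(C=O)c2c1`: 66 nM
compound 3 `CCCCc1ccc2[nH]c(-c3ccc(OC)cc3)c(/C=N/NC(=O)c3ccc(Cl)cc3)c2c1`: 220 nM

In a functional assay on MCF7 cells (Homo sapiens) for antiproliferative activity, with a stated time of 5 days (a higher number here means a weaker inhibitor, a lower number a stronger inhibitor), compound 1 gives 22 nM, while compound 2 gives 66 nM. The change between them is trifluoromethyl in place of methoxy on an aromatic carbon, and it produced a 3.0-fold higher number from compound 1 to compound 2 (0.48 log units; beyond the scatter). Compound 3 gives 220 nM in this assay; the difference between the core of compound 3 and that of compound 1 is not broken down here. Compound 4 `CCCCc1ccc2[nH]c(-c3ccc(C(F)(F)F)cc3)c(/C=N/NC(=O)c3ccc(Cl)cc3)c2c1` is not yet measured. It differs from compound 3 by trifluoromethyl in place of methoxy on an aromatic carbon, the same change that was made from compound 1 to compound 2. Because that earlier change gave a 3.0-fold higher number from compound 1 to compound 2 (0.48 log units; beyond the scatter), a step of similar size is expected here, and the expected step in this assay is a 3.0-fold higher number from compound 3 to compound 4 (0.47 log units; beyond the scatter). On this basis compound 4 is estimated at 650 nM in this assay.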

Compound 4, half-maximal inhibitory concentration: 1060 nM
Compound 4: the middle estimate sits 1.6-fold (0.21 log units) below what was measured; measured number inside the range.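

In this assay, the change from 4-methoxyphenyl to 4-(trifluoromethyl)phenyl moved the number in the same direction on the second core, giving a 4.8-fold higher number from compound 3 to compound 4 (0.68 log units; beyond the scatter). The two steps agree in direction, and their sizes cannot be told apart: the same change on two cores in this assay, a 3.0-fold higher number (0.48 log units; beyond the scatter) from compound 1 to compound 2 and a 4.8-fold higher number (0.68 log units; beyond the scatter) from compound 3 to compound 4, 1.6-fold (0.21 log units) apart, within the scatter of two such steps. This shows that the change carried over between these two cores, but two pairs say nothing about other cores and do not explain why the number rises.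

The compounds shown leave open how an amine or a carboxylic acid in place of the methoxy group would compare. They also leave open whether the step would hold with a longer chain in place of the butyl chain.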